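Homologated alpha chain in a bicyclic prostaglandin analogue

The compounds below may be only part of what the source reports. "The series", "measured", "known", "first", "only" and "open" are said of these compounds alone.

Measured compounds:
compound 1, `O=C(O)CCC/C=C\C[C@H]1C(=O)C[C@@H](O)[C@@H]1/C=C/[C@@H](O)COc1ccccc1` — 16 nM
compound 2, `O=C(O)CCC1=CC[C@@H]2[C@@H](/C=C/[C@@H](O)COc3ccccc3)[C@H](O)C[C@@H]2OC1` — 530 nM

In a functional assay on CHO cells for agonist activity at prostaglandin F2-alpha receptor (Homo sapiens), read by fluorescence and calcium flux (on this read-out lower numbers stand for an effect already at smaller amounts and higher numbers for an effect only at larger amounts of compound), compound 1 gives 16 nM, while compound 2 gives 530 nM, the higher of the two numbers and beyond the scatter. Compound 3, `O=C(O)CCCC1=CC[C@@H]2[C@@H](/C=C/[C@@H](O)COc3ccccc3)[C@H](O)C[C@@H]2OC1`, has not been measured in this assay. It differs from compound 2 in one place: carboxymethyl in place of carboxy on a saturated chain carbon, two bonds along the chain from a double-bonded ring carbon, so the acid sits one bond further from the shared core. Among the measured compounds shown here, no measured pair shows this kind of chain lengthening, so the size of the step can only be judged from compound 2 alone. Compound 3 is expected to lie somewhat higher in this assay than compound 2, with a step of roughly a 3.8-fold higher number from compound 2 to compound 3 (0.58 log units; beyond the scatter), though a result within the scatter cannot be excluded. The estimate for compound 3 is 2000 nM, within a range from 500 nM to 8000 nM.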

Compound 3, half-maximal effective concentration: 640 nM
Estimate against measurement, compound 3: 3.1-fold (0.49 log units) above; the range from low to high includes it.
By their numbers in this assay, from the lowest: compound 1; then compounds 2 and 3 (each within the scatter of the next).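

In this assay, replacing carboxy with carboxymethyl on a saturated chain carbon, two bonds along the chain from a double-bonded ring carbon, amounts to a 1.2-fold higher number from compound 2 to compound 3 (0.08 log units; within the scatter) and gives the first measured size for this change. On this read-out, the two compounds cannot be told apart, so placing the acid one bond further from the shared core has no effect that can be distinguished at this position. Nothing available bears on why the result falls this way.

The compounds shown leave open whether an even longer chain ending in a carboxylic acid would also stay within the scatter of these two compounds. They also leave open how an ester or an amide in place of the carboxylic acid would read out at this position on the shared core.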